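This account rests on a few compounds, and the source may have more. Where it says the series, first, only, none or still open, it means among the compounds named here.

Measured in an ADME assay on MT4 cells (Homo sapiens) for cytotoxicity, read by MTT assay, with a stated time of 4 days; a lower number here means that less compound is tolerated, a higher number that more compound is tolerated:
compound 1 `Cc1cc(-c2ccccc2C(F)(F)F)cc(C)c1Nc1ccnc(Nc2ccc(C#N)cc2)n1` gives 4210 nM
compound 2 `Cc1cc(-c2ccc(F)cc2)cc(C)c1Nc1ccnc(Nc2ccc(C#N)cc2)n1` gives 4170 nM
compound 3 `Cc1cc(-c2cccc(C(F)(F)F)c2)cc(C)c1Nc1ccnc(Nc2ccc(C#N)cc2)n1` gives 4030 nM

Compound 3 sits alongside the other two: the step of a 1.0-fold lower number from compound 1 to compound 3 (0.02 log units; within the scatter) and the step of a 1.0-fold lower number from compound 2 to compound 3 (0.01 log units; within the scatter) are both within the scatter, as is a 1.0-fold lower number from compound 1 to compound 2 (0.00 log units; within the scatter), so in this assay the three compounds cannot be told apart on the numbers shown.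

Compound 4 `Cc1cc(-c2ccccc2Cl)cc(C)c1Nc1ccnc(Nc2ccc(C#N)cc2)n1` has not yet been measured. Relative to compound 3 the change is 2-chlorophenyl in place of 3-(trifluoromethyl)phenyl on an aromatic carbon. It sits on an aromatic carbon of a six-membered aromatic ring of carbon only, meta to two methyl groups, para to a large group, which is the same place at which compounds 1, 2 and 3 already differ from one another. The three variations already seen at this place, a 1.0-fold lower number from compound 1 to compound 2 (0.00 log units; within the scatter), a 1.0-fold lower number from compound 1 to compound 3 (0.02 log units; within the scatter) and a 1.0-fold lower number from compound 2 to compound 3 (0.01 log units; within the scatter), all stayed within the scatter, so a 2-chlorophenyl in that place is expected to give no step beyond the scatter either, a 1.0-fold higher number from compound 3 to compound 4 (0.01 log units; within the scatter). Compound 4 is accordingly estimated at 4100 nM, with a range from 2000 nM to 8500 nM.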

Compound 4, half-maximal cytotoxic concentration: 3990 nM
The estimate for compound 4 lay 1.0-fold (0.01 log units) above the measured number; measured number inside the range.
By their numbers in this assay, from the lowest: compounds 4, 3, 2 and 1 (each within the scatter of the next).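

Notes on the aryl group at this place: in this assay, 2-chlorophenyl is the first group here carrying chlorine instead of fluorine, and it still cannot be separated from the others, with a 1.0-fold lower number from compound 3 to compound 4 (0.00 log units; within the scatter) and a 1.0-fold lower number from compound 2 to compound 4 (0.02 log units; within the scatter). The closest comparison, chloro in place of trifluoromethyl on the same phenyl group, gives a 1.1-fold lower number from compound 1 to compound 4 (0.02 log units; within the scatter), so this exchange also leaves the number unresolved, as does the drop from 10 heavy atoms in 3-(trifluoromethyl)phenyl to 7 in 2-chlorophenyl. No evidence is available to account for this flat reading.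

All four groups at this place are phenyl rings carrying fluorine or chlorine. Still open, as far as these compounds go, is whether an aminomethyl group or a carboxylic acid on that phenyl, or a longer alkyl chain in its place, would stay within the same narrow band.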